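The compounds below may be only part of what the source reports. "The series", "measured", "known", "first", "only" and "open" are said of these compounds alone.

Compound 1 `CN(C)CCCCOc1ccc2oc(-c3ccccc3)cc(=O)c2c1` gives 720 nM in an assay on isolated protein (Cavia porcellus) with Sigma non-opioid intracellular receptor 1 (Homo sapiens) as the target, read by radioligand binding; a lower number here means a stronger inhibitor, a higher number a weaker inhibitor.
Compound 2 `CN(C)CCCCCCCCOc1ccc2oc(-c3ccccc3)cc(=O)c2c1` gives 227 nM.
Compound 3 `O=c1cc(-c2ccccc2)oc2ccc(OCCCCCCN3CCC(O)CC3)cc12` gives 100 nM.

Among these three measured compounds, compound 1 stands with the highest number, which here means the weakest inhibition. Compound 2 is a 3.2-fold lower number from compound 1 to compound 2 (0.50 log units; beyond the scatter), and compound 3 is a 7.2-fold lower number from compound 1 to compound 3 (0.86 log units; beyond the scatter).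

Compound 4 `O=c1cc(-c2ccccc2)oc2ccc(OCCCCCCN3CCCCC3)cc12` has not yet been measured. Compared with compound 1, the change is 2-(piperidin-1-yl)ethyl in place of dimethylamino on a saturated chain carbon, four bonds along the chain from an oxygen on an aromatic ring. The chain therefore grows and a ring replaces the two small groups on the nitrogen, while the count of hydrogen-bond donors and acceptors stays the same.

Among the compounds with values here, two measured steps bear on this. Lengthening the chain alone gave a 3.2-fold lower number from compound 1 to compound 2 (0.50 log units; beyond the scatter). Lengthening the chain and adding a ring that also carries a hydroxyl gave a 7.2-fold lower number from compound 1 to compound 3 (0.86 log units; beyond the scatter). Compound 4 shares the longer chain and the ring but lacks the hydroxyl, so its step is expected to fall between those two. The expected step is a 5.5-fold lower number from compound 1 to compound 4 (0.74 log units; beyond the scatter), downward, beyond the scatter. The estimate for compound 4 in this assay is 130 nM, with a range from 55 nM to 310 nM.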

Compound 4, half-maximal inhibitory concentration: 101 nM
For compound 4 the middle estimate is 1.3-fold (0.11 log units) above the measured one, within the range that was stated.
By their numbers in this assay, from the lowest: compounds 3 and 4 (each within the scatter of the next); then compound 2; then compound 1.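

In this assay the hydroxy group on the ring of compound 3 turns out to make no visible difference, since replacing it with hydrogen gives a 1.0-fold higher number from compound 3 to compound 4 (0.00 log units; within the scatter) and so stays within the scatter. The full size of the drop seen earlier, now a 7.1-fold lower number from compound 1 to compound 4 (0.85 log units; beyond the scatter), is therefore reached with a plain piperidin-1-yl ring, and the hydroxy group is not needed for it on this chain. The ring on the shorter chain also does better than dimethylamino on the longer one, with a 2.2-fold lower number from compound 2 to compound 4 (0.35 log units; beyond the scatter), so lengthening the chain further is not the only way to lower the number, and no measurement shown here gives a reason for any of these steps.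

The compounds shown leave open how much of the drop from compound 1 comes from the chain and how much from the ring, a question that dimethylamino on the chain of compound 4, or piperidin-1-yl on the chain of compound 1, would separate. Also open, on these data alone, is whether the ring tolerates other changes, such as a methoxy group or a carboxylic acid in place of the hydroxy group, or a morpholine ring in place of the piperidine.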